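Isopropylcarbonyl in place of isobutyl: an untested analogue

The source may report more compounds than this note shows. Statements on the series, on what has been measured and on what is new or still open speak of the compounds shown alone.

Measured so far:
compound 1, `CC(C)COc1ccc2oc(/C=C/[S+](C)[O-])cc(=O)c2c1`: 1100 nM
compound 2, `Cc1cccc2oc(/C=C/[S+](C)[O-])cc(=O)c12`: 1300 nM

In a functional assay on A549 cells (Homo sapiens) for cytotoxicity, with a stated time of 48 h (a lower number here means a stronger inhibitor, a higher number a weaker inhibitor), compound 1 gives 1100 nM. Among the measured compounds shown here, the only other measured compound, compound 2, gives 1300 nM, a number within the usual scatter of the one for compound 1, so the two cannot be told apart on these data. Compound 1 holds the lower of the two numbers, but nothing more can be read from that.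

Compound 3, `CC(C)C(=O)Oc1ccc2oc(/C=C/[S+](C)[O-])cc(=O)c2c1`, has not yet been measured in this assay. It differs from compound 1 in one place: isopropylcarbonyl in place of isobutyl on an oxygen on an aromatic ring. For the measured compounds named here, no pair of measured compounds differs in this same way, so nothing measured here shows what this change does. The step of a 1.3-fold higher number from compound 1 to compound 3 (0.10 log units; within the scatter) is therefore expected to stay within the scatter, or only slightly beyond it, in either direction. The estimate for compound 3 is 1400 nM, with a range from 500 nM to 4000 nM.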

Compound 3, half-maximal inhibitory concentration: 2400 nM
Compound 3: the middle estimate sits 1.7-fold (0.23 log units) below what was measured, and the stated range covers the measured number.
By their numbers in this assay, from the lowest: compounds 1, 2 and 3 (each within the scatter of the next, the first and the last beyond it).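

In this assay, isopropylcarbonyl in place of isobutyl on an oxygen on an aromatic ring gives a 2.2-fold higher number from compound 1 to compound 3 (0.34 log units; beyond the scatter), a modest step. This shows that the position responds to a change of group: the isobutoxy and (isopropylcarbonyl)oxy compounds can be told apart, and the isobutoxy compound holds the lower number. Nothing measured here accounts for the size or direction of this step.

This single pair does not separate the contribution of the carbonyl from that of the change in the carbon chain. As far as these compounds go, whether a longer alkyl chain, a carbamoyl group or an amine-bearing chain on this oxygen would give a lower or a higher number than isobutyl remains open.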